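This account rests on a few compounds, and the source may have more. Where it says the series, first, only, none or still open, it means among the compounds named here.

In a functional assay on isolated protein for inhibition of Glucose-dependent insulinotropic receptor (Homo sapiens), read by HTRF and cAMP accumulation (a higher number here means that more compound is needed for the effect, a lower number that less compound is needed), compound 1 `Cc1nc(S(C)(=O)=O)ccc1Oc1ncnc(OC2CCN(C(=O)OC(C)(C)C(F)(F)F)CC2)c1F` gives 6.53 nM, and compound 2 `Cc1nc(S(C)(=O)=O)ccc1Oc1ncnc(OC2CCN(C(=O)OC(C)(C)CF)CC2)c1F` gives 19.9 nM. Among the compounds with values here, the single measured step between them is a 3.0-fold higher number from compound 1 to compound 2 (0.48 log units; beyond the scatter). Within the data shown here, compound 2 therefore stands at the higher of the two numbers, with compound 1 as its only neighbour. Compound 3 `Cc1nc(S(C)(=O)=O)ccc1Oc1ncnc(OC2CCN(C(=O)O[C@H](C)CF)CC2)c1F` differs from compound 2 by 1-(fluoromethyl)ethyl in place of 1-(fluoromethyl)-1-methylethyl on an oxygen next to a carbonyl group. Among the measured compounds shown here, no measured step covers this particular change; the step from compound 1 to compound 2 is a different alteration of the same group, so it bears on the present step only loosely and gives no direction. A step of modest size, or none beyond the scatter, is therefore expected, a 1.3-fold higher number from compound 2 to compound 3 (0.10 log units; within the scatter). Compound 3 is accordingly estimated at 25 nM in this assay, with a range from 8 nM to 80 nM.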

Compound 3, half-maximal effective concentration: 196 nM
For compound 3 the middle estimate is 7.8-fold (0.89 log units) below the measured one, outside the stated range (above it).
By their numbers in this assay, from the lowest: compound 1; then compound 2; then compound 3.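

In this assay, within the data shown here, 1-(fluoromethyl)ethyl in place of 1-(fluoromethyl)-1-methylethyl on an oxygen next to a carbonyl group gives a 9.8-fold higher number from compound 2 to compound 3 (0.99 log units; beyond the scatter), so this position responds to the carbon count of the group, with 4 heavy atoms entering for 5, and not only to its fluorine content, the one thing the earlier pair varied. With the rest of the structure unchanged, this group alone spans a 30-fold higher number from compound 1 to compound 3 (1.48 log units; beyond the scatter). The data shown offer nothing that accounts for these steps.

The compounds shown leave open what the opposite configuration at the defined stereocentre of compound 3 would give. They also leave open how a 1-(trifluoromethyl)ethyl group, a cyclopropyl ring or a longer chain on that oxygen would compare with compound 1 and compound 3.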